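Taking the bromo group off compound 2

The source may hold more compounds than are shown below. What is called first, only, known or untested is meant among the compounds shown, and "the series" means these compounds.

In a functional assay on A549 cells (Homo sapiens) for inhibition, read by sulforhodamine B assay, with a stated time of 48 h (a lower number here means a stronger inhibitor, a higher number a weaker inhibitor), compound 1 `COC(=O)[C@H]1C[C@@H](c2coc3ccccc3c2=O)N(c2ccccc2)O1` gives only a limit, > 60000 nM. Among the compounds with values here, compound 2 `O=c1c([C@@H]2C[C@H](c3ccccc3)ON2c2ccccc2)coc2ccc(Br)cc12` gives 51000 nM, the only actual number so far, so no measured step is available as a guide. Compound 3 `O=c1c([C@@H]2C[C@H](c3ccccc3)ON2c2ccccc2)coc2ccccc12` has hydrogen in place of bromo on an aromatic carbon, a change counted as hydrogen in place of bromo on an aromatic carbon. Only a small shift towards weaker inhibition is expected, possibly none beyond the usual scatter. The expected step is a 1.2-fold higher number from compound 2 to compound 3 (0.07 log units; within the scatter). For compound 3 the estimated value is 60000 nM, within an expected range of 30000 nM to 120000 nM.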

Compound 3, half-maximal inhibitory concentration: > 60000 nM
Compound 3: no number, only a limit (the forecaster's own chance of this, stated with the estimate: 55%); the middle value sits exactly at the limit.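

In this assay, putting hydrogen in place of bromo gives an at least 1.1-fold higher number from compound 2 to compound 3 (0.07 log units; that floor lies within the scatter), which is a floor and not a measured size. Compound 3 gives only a limit, so the true effect of removing bromo from this position could be larger than that floor. The step between compound 1 and compound 3 cannot be read, and most of the series sits at one ceiling: the limit of > 60000 nM in this assay, at which 2 of the 3 values shown sit.

On these data alone, whether chloro, methoxy or an amine at this position would give a real number, stronger than compound 2, remains open.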